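The source may hold more compounds than are shown below. What is called first, only, known or untested is meant among the compounds shown, and "the series" means these compounds.

Measured compounds:
compound 1 `Cc1nc(N(C)C2CCCC2)nc2ccc(NC(=O)/C=C/c3ccc(Cl)cc3)cc12` – 399 nM
compound 2 `Cc1nc(N2CCC(N3CCCC3=O)CC2)nc2ccc(NC(=O)/C=C/c3ccc(Cl)cc3)cc12` – 74 nM

In an assay on CHO-K1 cells for displacement of a labelled ligand from melanin-concentrating hormone receptor 1 (Homo sapiens), read by scintillation proximity assay, with a stated time of 2 h (on this read-out lower numbers stand for stronger inhibition and higher numbers for weaker inhibition), compound 1 gives 399 nM and compound 2 gives 74 nM. Compound 2 holds the lowest number of the two, and compound 1 stands well above it, beyond the usual scatter. Compound 3 `Cc1nc(N2CCC(O)CC2)nc2ccc(NC(=O)/C=C/c3ccc(Cl)cc3)cc12` has not yet been measured; it differs from compound 2 by hydroxy in place of 2-oxopyrrolidin-1-yl on a saturated ring carbon. Within the data shown here, no measured pair shows this change, and nothing among the measured compounds tells what this part of compound 2 contributes, so the step can only be estimated. A move toward higher numbers in this assay is expected, but a moderate one, not as wide as the gap between compound 1 and compound 2. The step of a 2.7-fold higher number from compound 2 to compound 3 (0.43 log units; beyond the scatter) is the expected size of that shift. Compound 3 is estimated at 200 nM, with a range from 60 nM to 700 nM.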

Compound 3, half-maximal inhibitory concentration: 107 nM
Compound 3: middle estimate off by 1.9-fold (0.27 log units), on the high side; measured number inside the range.
By their numbers in this assay, from the lowest: compounds 2 and 3 (each within the scatter of the next); then compound 1.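

In this assay, hydroxy in place of 2-oxopyrrolidin-1-yl on the saturated ring carbon gives a 1.4-fold higher number from compound 2 to compound 3 (0.16 log units; within the scatter), so at this position the five-membered non-aromatic ring and its carbonyl can be exchanged for hydroxy with no change beyond the scatter. The exchange of cyclopentyl(methyl)amino for 4-hydroxypiperidin-1-yl on the aromatic carbon gives a 3.7-fold lower number from compound 1 to compound 3 (0.57 log units; beyond the scatter), a modest step beyond the scatter, so the gain seen with compound 2 does not depend on the 2-oxopyrrolidin-1-yl group. No measurement on these compounds accounts for either step.

The compounds shown leave open how an amine, a carboxylic acid or a longer chain on the same ring carbon would read, and whether any group is needed there at all. Going by these compounds, the rest of the structure is the same in all three compounds, so it also remains open whether this result holds with other groups elsewhere on the shared core.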